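The compounds below may be only part of what the source reports. "The series", "measured", "known", "first", "only" and "open" are said of these compounds alone.

Compound 1 `CCCc1cc(N)c2cc(NC(=O)/C=C/c3ccc(O)cc3)ccc2n1` gives 1100 nM. Compound 2 `CCCc1cc(N)c2cc(NC(=O)/C=C/c3ccc(SC)cc3)ccc2n1` gives 9 nM. Compound 3 `CCCc1cc(N)c2cc(NC(=O)/C=C/c3cccc(Cl)c3)ccc2n1` gives 1100 nM.

These three numbers come from an assay on isolated protein for displacement of a labelled ligand from melanin-concentrating hormone receptor 1 (Homo sapiens); a higher number here means a weaker inhibitor, a lower number a stronger inhibitor. Compound 2 stands lowest of the three: the steps are a 120-fold lower number from compound 1 to compound 2 (2.09 log units; beyond the scatter) and a 120-fold higher number from compound 2 to compound 3 (2.09 log units; beyond the scatter), both large, while from compound 1 to compound 3 there is no change at the digits printed from compound 1 to compound 3 (within the scatter). The next compound, compound 4 `CCCCc1ccc(/C=C/C(=O)Nc2ccc3nc(CCC)cc(N)c3c2)cc1`, is reached from compound 2 by one change: butyl in place of methylsulfanyl on an aromatic carbon. Among the measured compounds shown here, two measured steps bear on this position of the ring. Both replacements of the methylsulfanyl group seen so far, by hydroxy in compound 1 and by a 3-chlorophenyl arrangement in compound 3, raised the number by a large amount, so the methylsulfanyl group appears to carry much of the low number of compound 2. Butyl, however, has not been measured, and it keeps a group without donors in the same place. A moderate rise is therefore expected: for compound 4 the estimate is 60 nM, between 10 nM and 400 nM, an expected step of a 6.7-fold higher number from compound 2 to compound 4 (0.82 log units; beyond the scatter).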

Compound 4, half-maximal inhibitory concentration: 45 nM
Compound 4: the middle estimate sits 1.3-fold (0.12 log units) above what was measured, and the stated range covers the measured number.
By their numbers in this assay, from the lowest: compound 2; then compound 4; then compounds 1 and 3 (each within the scatter of the next).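

In this assay, the butyl group shows that a low number at this place on the ring does not depend on the methylsulfanyl group alone: the exchange costs only a modest step (a 5.0-fold higher number from compound 2 to compound 4 (0.70 log units; beyond the scatter)), although butyl is a chain of carbon only, with no hydrogen-bond acceptor. Set against the hydroxy group, the same butyl group gives a large gain (a 24-fold lower number from compound 1 to compound 4 (1.39 log units; beyond the scatter)), so the two replacements of methylsulfanyl at this place differ widely, while compound 2 still holds the lower number. Nothing measured here explains either step.

The compounds shown leave open how a methoxy group, an amine or a longer chain at this place would compare with butyl and methylsulfanyl. They also leave open whether the order of these groups would hold if the propyl chain on the shared core were changed.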